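Replacing an oxadiazole with methoxy: cytotoxicity on BJ cells

The source may hold more compounds than are shown below. What is called first, only, known or untested is meant among the compounds shown, and "the series" means these compounds.

Compound 1, `CCOC(=O)CCCCCOc1cccc(CN(C(=O)c2ccc(-c3cccc(C(C)=O)c3)cc2)C(C)C)c1`: in an ADME assay on BJ cells (Homo sapiens) for cytotoxicity, read by CellTiter-Glo and resazurin assay, with a stated time of 72 h (on this read-out higher numbers stand for an effect only at larger amounts of compound and lower numbers for an effect already at smaller amounts), compound 1 gives > 26000 nM, which is a limit of the assay.
Compound 2, `CCOC(=O)CCCCCOc1cccc(CN(C(=O)c2ccc(-c3cccc(Oc4ccccc4)c3)cc2)C(C)C)c1`: in this assay compound 2 gives > 19600 nM, again a limit.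
Compound 3, `CCOC(=O)CCCCCOc1cccc(CN(C(=O)c2ccc(-c3cccc(-c4nnc(C)o4)c3)cc2)C(C)C)c1`: in this assay compound 3 gives > 26000 nM, also a limit.

Compound 3 thus stands at a limit, as do the other two measured compounds; no numbered value exists for any of them. Compound 4, `CCOC(=O)CCCCCOc1cccc(CN(C(=O)c2ccc(-c3cccc(OC)c3)cc2)C(C)C)c1`, is not yet measured. It differs from compound 3 by methoxy in place of 5-methyl-1,3,4-oxadiazol-2-yl on an aromatic carbon.

The measured steps bear on this change only loosely. The step that the two limits leave unreadable from compound 1 to compound 3 and the step that the two limits leave unreadable from compound 2 to compound 3 both end at compound 3, and the step that the two limits leave unreadable from compound 1 to compound 2 links the other two, yet none of them has a readable size because the limit of > 19600 nM in this assay, at which 1 of the 3 values shown sits, and the limit of > 26000 nM in this assay, at which 2 of the 3 values shown sit, cap every value. No step beyond the scatter is therefore expected for the change to compound 4; the expected step that the limit leaves unreadable from compound 3 to compound 4 is essentially flat.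

For compound 4 in this assay the estimate is 30000 nM, with an expected range from 15000 nM to 60000 nM, most likely again reported as a limit.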

Compound 4, half-maximal effective concentration: > 21000 nM
Compound 4 was reported as a limit; the forecaster's own chance of this, stated with the estimate: 85%; the middle value does not contradict the limit.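

Compound 4, like compound 1, compound 2 and compound 3, is reported only as a limit, so the steps from compound 4 to each of them cannot be read. Left open is whether swapping methoxy, acetyl, phenoxy or 5-methyl-1,3,4-oxadiazol-2-yl changes the half-maximal effective concentration in this assay at all.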